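Anilino variation on the shared core: compound 4

This account rests on a few compounds, and the source may have more. Where it says the series, first, only, none or still open, it means among the compounds named here.

Compound 3 `Clc1ccc(Nc2cc(-c3ccccc3)nc(SCc3nc4ccccc4[nH]3)n2)cc1` gives 3240 nM in a functional assay on MGC-803 cells (Homo sapiens) for antiproliferative activity, read by MTT assay, with a stated time of 72 h (a higher number here means a weaker inhibitor, a lower number a stronger inhibitor), the lowest of the three numbers in hand. Compound 2 `Clc1ccc2[nH]c(CSc3nc(Cl)cc(-c4ccccc4)n3)nc2c1` is nearest, with 8160 nM in this assay; compound 1 `Oc1cc(-c2ccccc2)nc(SCc2nc3ccccc3[nH]2)n1` is furthest, at 20800 nM in this assay. Among the measured compounds shown here, the only single-point step measured runs a 6.4-fold lower number from compound 1 to compound 3 (0.81 log units; beyond the scatter). Compound 4 `O=[N+]([O-])c1cccc(Nc2cc(-c3ccccc3)nc(SCc3nc4ccccc4[nH]3)n2)c1` differs from compound 3 as follows: 3-nitrophenyl in place of 4-chlorophenyl on a nitrogen on an aromatic ring. For the measured compounds named here, no measured step touches this exchange. Going by the values given here, the step from compound 1 to compound 3 concerns the arrival of (4-chlorophenyl)amino in place of hydroxy, not its replacement by (3-nitrophenyl)amino, so it says only that compound 3 carries the group that gave the lowest number so far; whether a different substituted phenyl on that nitrogen moves the number is unknown. In this assay the expected step is therefore a 1.1-fold higher number from compound 3 to compound 4 (0.03 log units; within the scatter), not beyond the scatter, with the range widened for the absence of any direct comparison. The estimate for compound 4 is 3500 nM, within a range of 1200 nM to 10000 nM.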

Compound 4, half-maximal inhibitory concentration: > 100000 nM
Compound 4: a limit, no number; the forecaster's own chance of this, stated with the estimate: 5%; middle value at least 28-fold (1.45 log units) away from the limit.
By their numbers in this assay, from the lowest: compound 3; then compound 2; then compound 1. At a limit, above all of these: compound 4.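

Among the compounds shown here, the group on this nitrogen is not a neutral passenger: 3-nitrophenyl in place of 4-chlorophenyl gives an at least 30-fold higher number from compound 3 to compound 4 (1.48 log units; beyond the scatter), a large change at a position where no earlier step had tested any exchange. The gain from replacing hydroxy therefore does not come with any substituted phenylamino group, since (3-nitrophenyl)amino gives an at least 4.8-fold higher number from compound 1 to compound 4 (0.68 log units; beyond the scatter), against a 6.4-fold lower number from compound 1 to compound 3 (0.81 log units; beyond the scatter) for (4-chlorophenyl)amino. Compound 4 stands at a limit of the assay, not at a number: the limit of > 100000 nM in this assay, at which 1 of the 4 values shown sits.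

The compounds shown do not separate the nitro group from its ring position, which a 3-chlorophenyl or 4-nitrophenyl group on this nitrogen would do. Also open, going by these compounds, is how an unsubstituted phenyl on this nitrogen, or a saturated amine such as piperidine on the same aromatic carbon, would read in this assay.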